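Amide cap variation and cytotoxicity in the shared-core series

The source may hold more compounds than are shown below. What is called first, only, known or untested is meant among the compounds shown, and "the series" means these compounds.

Compound 1 `O=C(CC1CCOCC1)Nc1ccc(N2CCN(c3ccc(OC[C@@H]4CO[C@@](Cn5cncn5)(c5ccc(Cl)cc5Cl)O4)cc3)CC2)cc1`: in a toxicity assay on L02 cells (Homo sapiens) for inhibition, read by MTT assay, with a stated time of 48 h (a lower number here means a stronger inhibitor, a higher number a weaker inhibitor), only a limit, > 50000 nM.
Compound 2 `O=C(CCc1ccccc1)Nc1ccc(N2CCN(c3ccc(OC[C@@H]4CO[C@@](Cn5cncn5)(c5ccc(Cl)cc5Cl)O4)cc3)CC2)cc1`: in this assay only a limit, > 50000 nM.
Compound 3 `Cc1ccc(C(=O)Nc2ccc(N3CCN(c4ccc(OC[C@@H]5CO[C@@](Cn6cncn6)(c6ccc(Cl)cc6Cl)O5)cc4)CC3)cc2)o1`: in this assay only a limit, > 50000 nM.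

Compound 2 stands at the top of the measured range of this assay, and the two further values shown sit at the same limit, so no order among the three compounds can be read. The three measured steps, a step that the two limits leave unreadable from compound 1 to compound 2, a step that the two limits leave unreadable from compound 1 to compound 3 and a step that the two limits leave unreadable from compound 2 to compound 3, are all unreadable in size and direction, because of the limit of > 50000 nM in this assay, at which 3 of the 3 values shown sit.

Compound 4 `O=C(Nc1ccc(N2CCN(c3ccc(OC[C@@H]4CO[C@@](Cn5cncn5)(c5ccc(Cl)cc5Cl)O4)cc3)CC2)cc1)c1cccs1` carries the change (thiophen-2-yl in place of phenethyl on a carbonyl carbon). Within the data shown here, the step most closely related to it is the one from compound 2 to compound 3, which exchanges the same phenethyl for a five-membered heteroaromatic ring, and it too is unreadable. The evidence on the amide cap therefore gives no sign that any of these changes moves the read-out off the limit, and none is expected here: the step that the limit leaves unreadable from compound 2 to compound 4 is expected to stay within the scatter. Compound 4 is accordingly expected to give about 80000 nM in this assay, with a range of 30000 nM to 250000 nM, most likely reported again as a limit rather than a number.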

Compound 4, half-maximal inhibitory concentration: > 50000 nM
Compound 4: only a limit was reported; the forecaster's own chance of this, stated with the estimate: 85%; the middle value lies beyond the limit too.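

In this assay compound 4 gives > 50000 nM, again a limit and not a number. No new step can be read from compound 4 to compound 1, compound 2 or compound 3, because all four values rest on one shared limit: the limit of > 50000 nM in this assay, at which 4 of the 4 values shown sit.

The compounds shown leave open whether the amide caps differ at all in this read-out.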